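The source may report more compounds than this note shows. Statements on the series, on what has been measured and on what is new or still open speak of the compounds shown alone.

Compound 1 `COc1cc(/C=C2\CN(C)C/C(=C\c3ccc(Cl)c(Cl)c3)C2=O)cc(OC)c1`: 3260 nM
Compound 2 `COc1cc(/C=C2\CN(C)C/C(=C\c3cccc([N+](=O)[O-])c3)C2=O)cc(OC)c1`: 1770 nM
Compound 3 `COc1cc(/C=C2\CN(C)C/C(=C\c3ccc(Cl)c(Cl)c3)C2=O)cc(OC)c1OC`: 5330 nM

Three compounds built on a shared core were tested in a functional assay on THP-1 cells (Homo sapiens) for cytotoxicity, read by MTT assay, with a stated time of 24 h; a lower number here means a stronger inhibitor, a higher number a weaker inhibitor. Compound 1 and compound 2 differ by 3-nitrophenyl in place of 3,4-dichlorophenyl on a double-bonded chain carbon bound to a double-bonded ring carbon, and this change made a 1.8-fold lower number from compound 1 to compound 2 (0.27 log units; within the scatter). The core of compound 3 differs from the core of compound 1 by methoxy in place of hydrogen on an aromatic carbon, which gave a 1.6-fold higher number from compound 1 to compound 3 (0.21 log units; within the scatter). Compound 2 and compound 3 were not compared as a single step; their two values simply stand apart.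

Compound 4 `COc1cc(/C=C2\CN(C)C/C(=C\c3cccc([N+](=O)[O-])c3)C2=O)cc(OC)c1OC` has not yet been tested in this assay. It differs from compound 3 by 3-nitrophenyl in place of 3,4-dichlorophenyl on a double-bonded chain carbon bound to a double-bonded ring carbon, the same change, at the same place, that separates compound 1 from compound 2. Because that change earlier gave a 1.8-fold lower number from compound 1 to compound 2 (0.27 log units; within the scatter), a step of similar size is expected here, and the estimated step is a 1.8-fold lower number from compound 3 to compound 4 (0.25 log units; within the scatter). Within the data shown here, this rests on only one earlier pair, so the expectation is loose. The expected value for compound 4 is 3000 nM, with a likely range from 1500 nM to 6000 nM.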

Compound 4, half-maximal inhibitory concentration: 890 nM
Compound 4: the middle estimate sits 3.4-fold (0.53 log units) above what was measured, and the stated range ends above it.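

In this assay, putting 3-nitrophenyl in place of 3,4-dichlorophenyl gave a 6.0-fold lower number from compound 3 to compound 4 (0.78 log units; beyond the scatter), so the direction of the earlier step carried over to the new core but its size did not: the same change on two cores in this assay, a 1.8-fold lower number (0.27 log units; within the scatter) from compound 1 to compound 2 and a 6.0-fold lower number (0.78 log units; beyond the scatter) from compound 3 to compound 4, 3.3-fold (0.51 log units) apart, beyond the scatter of two such steps. Methoxy in place of hydrogen on an aromatic carbon, with 3-nitrophenyl present, gave a 2.0-fold lower number from compound 2 to compound 4 (0.30 log units; within the scatter), and this step also depends on its partner group: the same change on two cores in this assay, a 1.6-fold higher number (0.21 log units; within the scatter) from compound 1 to compound 3 and a 2.0-fold lower number (0.30 log units; within the scatter) from compound 2 to compound 4, 3.3-fold (0.51 log units) apart, beyond the scatter of two such steps. The two changes therefore do not combine as independent steps in these four compounds, but both comparisons rest on the same single set of four values, so they show neither a general rule for the series nor why the steps differ.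

The compounds shown leave open whether this dependence on the core extends to other phenyl groups, such as one carrying a nitrile, an amine or a carboxylic acid in place of 3-nitrophenyl. They also leave open whether an ethoxy group or a longer chain in place of methoxy would change the size of these steps.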